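The source may report more compounds than this note shows. Statements on the series, on what has been measured and on what is new or still open speak of the compounds shown alone.

Measured so far in a functional assay on SW-620 cells (Homo sapiens) for cytotoxicity, read by MTT assay, with a stated time of 72 h; on this read-out lower numbers stand for stronger inhibition and higher numbers for weaker inhibition:
compound 1 `COc1ccc(/C=C2\CCC/C(=C\c3cccc(OC)c3OC)C2=O)cc1` gives 13600 nM
compound 2 `COc1ccc(/C=C2\CCC/C(=C\c3cccc(OC)c3OC)C2=O)cc1OC` gives 6400 nM

Among the measured compounds shown here, compound 1 stands at the highest of the two numbers; its nearest neighbour is compound 2, reached by a 2.1-fold lower number from compound 1 to compound 2 (0.33 log units; beyond the scatter), the only step in the set that differs in one place, a methoxy in place of hydrogen on an aromatic carbon. Compound 3 `COc1cccc(/C=C2\CCC/C(=C\c3ccc(O)c(O)c3)C2=O)c1OC` is not yet measured. It differs from compound 1 as follows: 3,4-dihydroxyphenyl in place of 4-methoxyphenyl on a double-bonded chain carbon bound to a double-bonded ring carbon. For the measured compounds named here, no measured pair shows this exchange; the step to compound 2 is the sole guide and bears on it only loosely, as the one change that added an oxygen substituent and gave a modestly lower number. On that basis a modest fall is expected, held with little confidence: the estimated step is a 1.5-fold lower number from compound 1 to compound 3 (0.18 log units; within the scatter). The expected value for compound 3 in this assay is 9000 nM, within a range from 3000 nM to 27000 nM.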

Compound 3, half-maximal inhibitory concentration: 6300 nM
Compound 3: middle estimate off by 1.4-fold (0.15 log units), on the high side; measured number inside the range.
By their numbers in this assay, from the lowest: compounds 3 and 2 (each within the scatter of the next); then compound 1.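

In this assay, 3,4-dihydroxyphenyl is accepted in place of 4-methoxyphenyl on a double-bonded chain carbon bound to a double-bonded ring carbon, giving a 2.2-fold lower number from compound 1 to compound 3 (0.33 log units; beyond the scatter) and showing that this position also takes a group with hydrogen-bond donors, which the leaving group lacks. Compound 2 gives 6400 nM and compound 3 gives 6300 nM; these two numbers lie within the scatter of each other, so the methoxy and hydroxy substitution patterns in these two compounds are not separated here. Nothing on hand accounts for the lower number of compound 3.

The exchange alters two ring substituents at once, so the share of each remains unresolved. A single hydroxy group, an amine or a carboxylic acid on this ring remains untested among the compounds shown.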